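Side group changes on the amide chain carbon

The source may report more compounds than this note shows. Statements on the series, on what has been measured and on what is new or still open speak of the compounds shown alone.

Compound 1 `O=C(CN(c1nc(Cl)nc2[nH]cnc12)C1CC1)NCC(=O)OCc1ccccc1` carries hydrogen on the chain carbon bound to an amide-type nitrogen and a carbonyl carbon; in a functional assay on the whole organism (Tail, strain ICR) with Mus musculus as the target, in the tail flick test, with a stated time of 120 min, at a dose of 25 umol/kg by the oral route (on this read-out lower numbers stand for a weaker effect and higher numbers for a stronger effect at the one dose given), compound 1 gives 21.7%. Compound 2 `C[C@@H](O)[C@H](NC(=O)CN(c1nc(Cl)nc2[nH]cnc12)C1CC1)C(=O)OCc1ccccc1` gives 30.7% and compound 3 `CC[C@H](C)[C@H](NC(=O)CN(c1nc(Cl)nc2[nH]cnc12)C1CC1)C(=O)OCc1ccccc1` gives 22%. Compound 3 is second highest of the three, nearest to compound 1 and furthest from compound 2, both gaps within the scatter. Compound 4 `NC(=O)C[C@H](NC(=O)CN(c1nc(Cl)nc2[nH]cnc12)C1CC1)C(=O)OCc1ccccc1` differs from compound 3 by carbamoylmethyl in place of sec-butyl on a saturated chain carbon bound to an amide-type nitrogen and a carbonyl carbon. The bearing steps are a number 9 percentage points higher from compound 1 to compound 2 (within the scatter), a number 0.3 percentage points higher from compound 1 to compound 3 (within the scatter) and a number 8.7 percentage points lower from compound 2 to compound 3 (within the scatter), none beyond the scatter. A step of similar size is therefore expected, with compound 4 estimated at 26% (range 12% to 40%), meaning an expected step of a number 4 percentage points higher from compound 3 to compound 4 (within the scatter).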

Compound 4, a percentage reported as activity, at one dose (the size of the read-out at that dose, not a potency): 15.1%
Compound 4: the middle estimate sits 10.9 percentage points above what was measured; low and high end bracket the measured number.
By their numbers in this assay, from the lowest: compounds 4, 1, 3 and 2 (each within the scatter of the next, the first and the last beyond it).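

Carbamoylmethyl on this chain carbon yields the first step beyond the scatter in this assay, with a number 15.6 percentage points lower from compound 2 to compound 4 (beyond the scatter), set against 1-hydroxyethyl. Against the other two groups the exchange gives a number 6.9 percentage points lower from compound 3 to compound 4 (within the scatter) and a number 6.6 percentage points lower from compound 1 to compound 4 (within the scatter), so among these side groups only the pair of 1-hydroxyethyl and carbamoylmethyl is separated. Nothing at hand accounts for that separation. Still open, as far as these compounds go, is how a carboxylic acid, a primary amine or a longer carbamoyl chain on this carbon would read in this assay.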